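Replacing ethoxy at the carbonyl of compound 1

The compounds below may be only part of what the source reports. "The series", "measured", "known", "first", "only" and "open" are said of these compounds alone.

Measured so far:
- compound 1 `CCOC(=O)Nc1cccc2c1CN(C)CC2c1ccccc1` gives about 4 mg/kg
- compound 2 `CCOC(=O)Nc1cccc2c1CN(C)CC2c1ccc(F)cc1` gives 3.3 mg/kg

Both numbers come from a functional assay on the whole organism for inhibition, with Mus musculus as the target; a lower number here means that less compound is needed, a higher number that more compound is needed for the effect. Among the compounds with values here, compound 1 has only one measured neighbour, and a 1.2-fold lower number from compound 1 to compound 2 (0.08 log units; within the scatter). The two compounds therefore cannot be ranked.

Compound 3 `CN1Cc2c(NC(=O)CN3CCCC3)cccc2C(c2ccccc2)C1` has not yet been measured. It differs from compound 1 by (pyrrolidin-1-yl)methyl in place of ethoxy on a carbonyl carbon, which in words is (pyrrolidin-1-yl)methyl in place of ethoxy on a carbonyl carbon.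

Within the data shown here, the single measured step is a poor guide, since it swaps hydrogen for fluoro on an aromatic carbon and leaves the carbonyl untouched. Among the measured compounds shown here, no measured compound varies the group on the carbonyl, so the size and direction of this larger swap are open. A moderate move to a higher number in this assay is a cautious expectation, no more.

The step expected is a 2.0-fold higher number from compound 1 to compound 3 (0.30 log units; within the scatter), and this is only a rough estimate. For compound 3 the estimated value is 8 mg/kg, with an expected range from 2 mg/kg to 35 mg/kg.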

Compound 3, dose for half-maximal effect: about 25 mg/kg
The estimate for compound 3 lay 3.1-fold (0.49 log units) below the measured number; measured number inside the range.
By their numbers in this assay, from the lowest: compounds 2 and 1 (each within the scatter of the next); then compound 3.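

The group on the carbonyl carbon matters in this assay: (pyrrolidin-1-yl)methyl in place of ethoxy gives a 6.3-fold higher number from compound 1 to compound 3 (0.80 log units; beyond the scatter), so more compound is needed for the effect. The earlier fluoro change on the aromatic carbon stayed within the scatter, whereas this change on the carbonyl carbon goes beyond it. No measurement is available that would explain this shift.

This single swap changes several things at once: the oxygen goes, while a nitrogen and a five-membered ring arrive, so the compounds shown cannot separate these contributions. On these data alone, an open-chain diethylamine in place of the pyrrolidine, a six-membered piperidine ring, or a longer chain between the carbonyl and the pyrrolidine would each test a different part of the change, and how any of them would read remains open.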